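The compounds below may be only part of what the source reports. "The series", "measured", "known", "first", "only" and "open" are said of these compounds alone.

Measured so far in a functional assay on HEK293 cells for positive allosteric modulation of metabotropic glutamate receptor 5 (Homo sapiens), read by FLIPR and calcium flux; a lower number here means that less compound is needed, a higher number that more compound is needed for the effect:
compound 1 `O=C(COCc1ccncn1)N1CCN(c2ccc(Cl)cc2Cl)CC1`, 2800 nM
compound 2 `O=C(COCc1ncccn1)N1CCN(c2ccc(Cl)cc2Cl)CC1`, 18000 nM

Within the data shown here, compound 2 holds the highest of the two numbers; the only measured step in this assay is a 6.4-fold higher number from compound 1 to compound 2 (0.81 log units; beyond the scatter). Compound 3 `N#Cc1ccc(COCC(=O)N2CCN(c3ccc(Cl)cc3Cl)CC2)s1` carries 5-cyanothiophen-2-yl in place of pyrimidin-2-yl on a saturated chain carbon bound to an oxygen on a saturated carbon. Among the measured compounds shown here, no measured step covers a thiophene or a nitrile at this place; the one step shows only that exchanging the ring at this place moved the number beyond the scatter. Since pyrimidin-2-yl gave the higher number of the two rings seen, compound 3 is expected to shift by a 3.6-fold lower number from compound 2 to compound 3 (0.56 log units; beyond the scatter), with wide uncertainty in either direction. The estimate for compound 3 is 5000 nM, between 1500 nM and 20000 nM.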

Compound 3, half-maximal effective concentration: 210 nM
Compound 3: middle estimate off by 24-fold (1.38 log units), on the high side; the whole stated range lies above it.
By their numbers in this assay, from the lowest: compound 3; then compound 1; then compound 2.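

In this assay the ring at this place has more range than the two pyrimidines showed: 5-cyanothiophen-2-yl gives a lower number than either pyrimidine (an 86-fold lower number from compound 2 to compound 3 (1.93 log units; beyond the scatter)) (a 13-fold lower number from compound 1 to compound 3 (1.12 log units; beyond the scatter)). The change alters the ring and adds a nitrile together, so these steps do not separate the contribution of the thiophene from that of the nitrile. No evidence on the origin of these steps is available.

Still open, as far as these compounds go, is whether unsubstituted thiophen-2-yl keeps the low number. Also open, from the compounds shown here alone, is whether a chlorine or a carboxamide can replace the nitrile on the thiophene.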